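The source may report more compounds than this note shows. Statements on the series, on what has been measured and on what is new or still open speak of the compounds shown alone.

Compound 1 `Cc1ccc(NCc2cn(-c3ccccc3)nc2-c2ccc(C(F)(F)F)cc2)cc1`: in an ADME assay on MDBK cells (Bos taurus) for cytotoxicity, read by MTT assay, with a stated time of 72 h (on this read-out lower numbers stand for higher toxicity in this test and higher numbers for lower toxicity in this test), compound 1 gives > 100000 nM, which is a limit of the assay and not a number.
Compound 2 `Cc1ccc(NCc2cn(-c3ccccc3)nc2-c2ccccc2)cc1`: in this assay compound 2 gives > 100000 nM, again only a limit.
Compound 3 `Cc1ccc(-c2nn(-c3ccccc3)cc2CNc2ccccc2)cc1`: in this assay compound 3 gives > 100000 nM, again only a limit.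

Compound 4 `Cc1ccc(-c2nn(-c3ccccc3)cc2CNc2ccc(C(F)(F)F)cc2)cc1` has not yet been measured. It differs from compound 3 by trifluoromethyl in place of hydrogen on an aromatic carbon. The same change is found between two measured compounds: compound 1 differs from compound 2 by trifluoromethyl in place of hydrogen on an aromatic carbon, and that step reads a step that the two limits leave unreadable from compound 2 to compound 1. The core of compound 3 and the core of compound 2 hold the same atoms joined differently; the difference between the two cores is not broken down here. All three measured values sit at the limit of > 100000 nM in this assay, at which 3 of the 3 values shown sit. For compound 4 the step that the limit leaves unreadable from compound 3 to compound 4 is expected to be small, resting on a step that the two limits leave unreadable from compound 2 to compound 1 and on (the limit of > 100000 nM in this assay, at which 3 of the 3 values shown sit). Compound 4 is expected to give 150000 nM, between 50000 nM and 500000 nM, most likely again only a limit.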

Compound 4, half-maximal cytotoxic concentration: > 100000 nM
Compound 4 gave a limit, no number (the forecaster's own chance of this, stated with the estimate: 85%); the middle value is on the limit's open side.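

Compound 3 and compound 4 both give only a limit, so no step can be read between them: the limit of > 100000 nM in this assay, at which 4 of the 4 values shown sit.

Left open is at what concentration, if any, these compounds turn toxic in this assay, and whether trifluoromethyl changes that.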